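Working notes: from compound 2 to compound 4

This account rests on a few compounds, and the source may have more. Where it says the series, first, only, none or still open, it means among the compounds named here.

Measured in a physicochemical assay for permeability, using PAMPA; on this read-out higher numbers stand for higher permeability and lower numbers for lower permeability:
- compound 1 `COCCOc1cc2oc(=O)n(CCC(=O)O)c2cc1Cl`: < 3 nm/s (a limit, not a number)
- compound 2 `C[C@@H](Oc1cc2oc(=O)n(CCC(=O)O)c2cc1Cl)c1ccc(F)cn1`: 31 nm/s
- compound 3 `O=C(O)CCn1c(=O)oc2cc(Cl)c(Cl)cc21`: 24 nm/s

Compound 2 at 31 nm/s and compound 3 at 24 nm/s lie within the usual scatter of each other. Compound 1 stands apart, resting on (the limit of < 3 nm/s in this assay, at which 1 of the 3 values shown sits).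

The next compound is compound 4 `C[C@@H](Oc1cc2oc(=O)n(CCC(=O)O)c2cc1Cl)c1cccnn1`, which carries pyridazin-3-yl in place of 5-fluoropyridin-2-yl on a saturated chain carbon bound to an oxygen on an aromatic ring and a saturated chain carbon.

Among the measured compounds shown here, only one measured step bears on this, and only indirectly: an at least 8.0-fold higher number from compound 1 to compound 3 (0.90 log units; beyond the scatter), with chloro in place of 2-methoxyethoxy on an aromatic carbon. For the measured compounds named here, that step lies at another place in the molecule, and no measured pair varies the group that changes here. It shows only that a single replacement in this series can move this assay beyond the scatter. A lower number is expected here, in a step smaller than that one, though still beyond the scatter. The expected step is a 3.1-fold lower number from compound 2 to compound 4 (0.49 log units; beyond the scatter). For compound 4 the estimate is 10 nm/s, with an expected range of 3.5 nm/s to 25 nm/s.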

Compound 4, apparent permeability: < 3 nm/s
Compound 4 gave a limit, no number (the forecaster's own chance of this, stated with the estimate: 15%); middle value at least 3.3-fold (0.52 log units) from the limit.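

At the saturated chain carbon bound to an oxygen on an aromatic ring and a saturated chain carbon, pyridazin-3-yl in place of 5-fluoropyridin-2-yl gives an at least 10-fold lower number from compound 2 to compound 4 (1.01 log units; beyond the scatter) in this assay. Among the compounds shown here, this is the first measured step at this place, and it shows that the group here is not a neutral passenger on this read-out: exchanging one six-membered aromatic ring for another, with no net charge on either group, is enough to go beyond the scatter. Compound 4 gives < 3 nm/s, which is a limit of the assay and not a number: the limit of < 3 nm/s in this assay, at which 2 of the 4 values shown sit.

Compound 1 and compound 4 both rest on limits, and the step between them cannot be read. The change also removes the fluorine and adds a second ring nitrogen in a single move, so the compounds shown do not separate the two, and it remains open whether an unsubstituted pyridin-2-yl or a phenyl at this place would stand nearer compound 2 or compound 4.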